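Working notes on the series: toward compound 4

This account rests on a few compounds, and the source may have more. Where it says the series, first, only, none or still open, it means among the compounds named here.

Of the compounds shown here, three sharing one core have been measured in an ADME assay on Vero cells (Chlorocebus sabaeus) for cytotoxicity, read by MTT assay, with a stated time of 48 h; a higher number here means that more compound is tolerated, a lower number that less compound is tolerated. Compound 1 `O=C(Nc1ccccc1)c1ccc([N+](=O)[O-])o1` gives 6700 nM in this assay. Compound 2 `O=C(NCCCc1ccccc1)c1ccc([N+](=O)[O-])o1` gives 11000 nM in this assay. Compound 3 `CN(C)c1ccc(C(C)(C)NC(=O)c2ccc([N+](=O)[O-])o2)cc1` gives 79000 nM in this assay, the highest of the three numbers; its gap to compound 2 and its gap to compound 1 both lie beyond the usual scatter, so compound 3 is the best tolerated of the measured set. For the measured compounds named here, no pair of these three compounds differs in one place only, so no single-change step is available as a guide.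

Compound 4 `CC(C)(NC(=O)c1ccc([N+](=O)[O-])o1)c1ccc(-c2ccc(Cl)cc2)cc1` differs from compound 3 in one place: 4-chlorophenyl in place of dimethylamino on an aromatic carbon. Going by the values given here, nothing measured so far follows such a change. Compound 4 is expected to be tolerated somewhat less well than compound 3, by a step of a 2.6-fold lower number from compound 3 to compound 4 (0.42 log units; beyond the scatter) in this assay, which may or may not exceed the scatter. Compound 4 is therefore estimated at 30000 nM in this assay, with a range from 8000 nM to 100000 nM.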

Compound 4, half-maximal cytotoxic concentration: > 140000 nM
Compound 4: no number, only a limit; the forecaster's own chance of this, stated with the estimate: 15%; middle value at least 4.6-fold (0.66 log units) from the limit.
By their numbers in this assay, from the lowest: compounds 1 and 2 (each within the scatter of the next); then compound 3. At a limit, above all of these: compound 4.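

Compound 4 stands in this assay at > 140000 nM, which is a limit of the assay and not a number: the limit of > 140000 nM in this assay, at which 1 of the 4 values shown sits. For the compounds shown here, on an aromatic carbon para to a large group, 4-chlorophenyl in place of dimethylamino gives an at least 1.7-fold higher number from compound 3 to compound 4 (0.24 log units; that floor lies within the scatter), the first single-change step. That floor lies within the scatter, so the change shows no loss of tolerance, and dimethylamino at this position is not required for the high number of compound 3, while the true size of any gain stays unread.

As far as these compounds go, whether an unsubstituted phenyl, a methoxy group or a lone chlorine at this position would hold the same tolerance remains open. One step also cannot separate the role of the chlorine from that of the added ring.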